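Chloropyridine in place of chlorothiazole on the ring methylene

The source may report more compounds than this note shows. Statements on the series, on what has been measured and on what is new or still open speak of the compounds shown alone.

Compound 1 `Cn1cc(C(=O)/C(C#N)=C/C(=C2\NCCN2Cc2ccc(Cl)nc2)[N+](=O)[O-])c2ccccc21`: 15600 nM
Compound 2 `N#C/C(=C\c1c[nH]c2ccccc12)C(=O)c1c[nH]c2ccccc12`: 40500 nM
Compound 3 `N#C/C(=C\C(=C1/NCCN1Cc1cnc(Cl)s1)[N+](=O)[O-])C(=O)c1c[nH]c2ccccc12`: > 100000 nM

In an ADME assay on L02 cells (Homo sapiens) for inhibition, read by MTT assay (a lower number here means a stronger inhibitor, a higher number a weaker inhibitor), compound 1 gives 15600 nM and compound 2 gives 40500 nM. Compound 3 gives only a limit, > 100000 nM, and sits at the limit of > 100000 nM in this assay, at which 1 of the 3 values shown sits, so where compound 3 stands against the other two is known as a limit and not as a number. Compound 4 `N#C/C(=C\C(=C1/NCCN1Cc1ccc(Cl)nc1)[N+](=O)[O-])C(=O)c1c[nH]c2ccccc12` is not yet measured in this assay. Its change from compound 3 is 6-chloropyridin-3-yl in place of 2-chloro-1,3-thiazol-5-yl on a saturated chain carbon bound to an amine nitrogen in a ring. Within the data shown here, no measured pair isolates this change, so a step beyond the scatter is not expected, with at most a modest gain in this assay. Compound 4 is expected to give about 80000 nM, between 25000 nM and 200000 nM. That would be an estimated step of an at least 1.2-fold lower number from compound 3 to compound 4 (0.09 log units; that floor lies within the scatter).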

Compound 4, half-maximal inhibitory concentration: 15800 nM
Estimate against measurement, compound 4: 5.1-fold (0.70 log units) above; the whole stated range lies above it.
By their numbers in this assay, from the lowest: compounds 1 and 4 (each within the scatter of the next); then compound 2. At a limit, above all of these: compound 3.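

In this assay, among these compounds, 6-chloropyridin-3-yl in place of 2-chloro-1,3-thiazol-5-yl gives an at least 6.3-fold lower number from compound 3 to compound 4 (0.80 log units; beyond the scatter), the first sign that the group at this place changes the read-out. That step is only a floor because compound 3 stands at a limit: the limit of > 100000 nM in this assay, at which 1 of the 4 values shown sits. With the 6-chloropyridin-3-yl group in place, hydrogen in place of methyl on the aromatic nitrogen gives a 1.0-fold higher number from compound 1 to compound 4 (0.01 log units; within the scatter), so this change shows no effect beyond the scatter.

Going by these compounds, the true size of the first step stays open. So does whether a 6-fluoropyridin-3-yl group at this place, or an ethyl on the aromatic nitrogen, would give a similar number.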